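This account rests on a few compounds, and the source may have more. Where it says the series, first, only, none or still open, it means among the compounds named here.

Within the data shown here, in an ADME assay (liver) for metabolic stability, with Liver microsome (Homo sapiens) as the target, read by LC-MS, using microsomes, with a stated time of 30 min, tested at 4 uM (a lower number here means that less of the compound is left, a higher number that more of the compound is left), three compounds with a shared core have numbers so far. In this test compound 1 `COCCn1c(-c2ccccc2Cl)nc2c(N3CCN4C(=O)CCC4C3)nc(C)nc21` gives 32% and compound 2 `CCN1CCN(c2nc(C)nc3c2nc(-c2ccccc2Cl)n3CC2CCOCC2)CC1` gives 41% while compound 3 `Cc1nc(N2CCN(C)CC2)c2nc(-c3ccccc3C(F)(F)F)n(C3CCOCC3)c2n1` gives 24% as its result. Compound 3 therefore stands within the usual scatter of compound 1 and clearly beneath compound 2, a gap beyond the scatter.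

Compound 4 `Cc1nc(N2CCN(C)CC2)c2nc(-c3ccccc3F)n(C3CCOCC3)c2n1` has not been measured yet. It differs from compound 3 in one place, with fluoro in place of trifluoromethyl on an aromatic carbon and the rest of the molecule unchanged. That carbon belongs to a six-membered aromatic ring of carbon only and sits ortho to a large group.

Among the measured compounds shown here, no two measured compounds differ in just one place, so the data give no direct guide to the size of such a step. Compound 3 at 24% is the starting point, and compound 2 at 41% shows that a number well over it is possible within this small set. A small upward step is expected, one that may stay inside the usual scatter. The estimated step of a number 7 percentage points higher from compound 3 to compound 4 (within the scatter) is expected to be modest in this assay and remains uncertain. For compound 4 the expected value is 31% with an estimated range from 17% to 48% across repeat measurements.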

Compound 4, percent of the compound remaining: 10%
For compound 4 the middle estimate is 21 percentage points above the measured one; the measured number lies below the stated range.
By their numbers in this assay, from the lowest: compound 4; then compounds 3, 1 and 2 (each within the scatter of the next, the first and the last beyond it).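

In this assay, among these compounds, the change from trifluoromethyl to fluoro gives a number 14 percentage points lower from compound 3 to compound 4 (beyond the scatter), and this is the first comparison in the set in which only one place differs. It shows that the group on this aromatic carbon, ortho to a large group, can by itself shift how much of the compound is left, even with the rest of the molecule unchanged, and that in this pair the fluoro compound is the one with less remaining. The data shown contain no measurement that bears on why the number moves in this direction.

The compounds shown leave open where a methoxy group, a nitrile or plain hydrogen on this same carbon would fall relative to trifluoromethyl and fluoro, and compound 1 and compound 2 cannot place chloro on that scale since they also differ elsewhere. As far as these compounds go, it also remains open whether the swap from trifluoromethyl to fluoro would give a similar step when other parts of the molecule are different.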